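A Fluoro-for-Methyl Swap on the Benzyl Group

A few compounds are considered here, and "the series" means these few. Any claim that something is new, unique, unknown or untested is made for them only; others in the source may bear on it.

Compound 1, `COc1ccc(-n2c(S)nnc2-c2cc(OC)c(OC)c(OC)c2)cc1`, 57500 nM in a functional assay on HepG2 cells (Homo sapiens) for inhibition, read by MTT assay, with a stated time of 48 h; a lower number here means a stronger inhibitor, a higher number a weaker inhibitor.
Compound 2, `CCSc1nnc(-c2cc(OC)c(OC)c(OC)c2)n1-c1ccc(OC)cc1`, a limit of this assay, > 60000 nM.
Compound 3, `COc1ccc(-n2c(SCc3ccc(C)cc3)nnc2-c2cc(OC)c(OC)c(OC)c2)cc1`, 31600 nM.
Compound 4, `COc1ccc(-n2c(SCc3ccc(F)cc3)nnc2-c2cc(OC)c(OC)c(OC)c2)cc1`, not yet measured.

Compound 3 gives the lowest of the two numbers shown in this assay. Its nearest neighbour is compound 1, and the step from compound 1 to compound 3 is a 1.8-fold lower number from compound 1 to compound 3 (0.26 log units; within the scatter), so the two sit within the scatter of each other. Compound 2 reaches only (the limit of > 60000 nM in this assay, at which 1 of the 3 values shown sits), which is a limit and not a number; the step from compound 2 to compound 3 is therefore an at least 1.8-fold lower number from compound 2 to compound 3 (0.27 log units; that floor lies within the scatter), and the step from compound 1 to compound 2 is an at least 1.0-fold higher number from compound 1 to compound 2 (0.01 log units; that floor lies within the scatter).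

Compound 4 differs from compound 3 in one place: fluoro in place of methyl on an aromatic carbon. Among the compounds with values here, none of the measured steps touches that position. Within the data shown here, the steps that do exist add or enlarge the group on the sulfur, and neither rises beyond the scatter, so the series so far shows no step beyond the scatter at all. A change of one heavy atom on the outer ring of the 4-methylbenzyl group is expected to behave likewise, and the step from compound 3 to compound 4 is estimated at a 1.0-fold higher number from compound 3 to compound 4 (0.01 log units; within the scatter). Compound 4 is accordingly expected to give about 32000 nM in this assay, within a range of 15000 nM to 60000 nM.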

Compound 4, half-maximal inhibitory concentration: 35000 nM
The estimate for compound 4 lay 1.1-fold (0.04 log units) below the measured number, and the stated range covers the measured number.
By their numbers in this assay, from the lowest: compounds 3, 4 and 1 (each within the scatter of the next). At a limit, above all of these: compound 2.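

In this assay, within the data shown here, the step of a 1.1-fold higher number from compound 3 to compound 4 (0.04 log units; within the scatter) is the first to touch this position, and it shows that fluoro in place of methyl on an aromatic carbon, para to a large group, leaves the number within the scatter. The 4-fluorobenzyl group on the sulfur also gives no step beyond the scatter when set against hydrogen on the sulfur, with a 1.6-fold lower number from compound 1 to compound 4 (0.22 log units; within the scatter), so the two benzyl compounds, which differ only at this position, both stay within the scatter of the compound with hydrogen there. Compound 2 enters only as a limit of the assay and not as a number, so its comparison is a floor, an at least 1.7-fold lower number from compound 2 to compound 4 (0.23 log units; that floor lies within the scatter), and it too shows nothing beyond the scatter: the limit of > 60000 nM in this assay, at which 1 of the 4 values shown sits.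

The compounds shown leave open whether an amine or a carboxylic acid at this position of the outer ring would give a step beyond the scatter. They also leave open whether a longer chain between the sulfur and that ring would do so.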